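Swapping a side chain where only limits are known

This account rests on a few compounds, and the source may have more. Where it says the series, first, only, none or still open, it means among the compounds named here.

In an ADME assay on CCRF-CEM cells (Homo sapiens) for cytotoxicity, with a stated time of 5 days (on this read-out lower numbers stand for stronger inhibition and higher numbers for weaker inhibition), compound 1 `CC(C)(CO)Nc1nc(N)nc2c1ncn2[C@H]1C[C@H](N=[N+]=[N-])[C@@H](CO)O1` gives > 100000 nM as a limit of the assay and not a number. Compound 2 `[N-]=[N+]=N[C@H]1C[C@H](n2cnc3c(NC4CC4)nc(Cl)nc32)O[C@@H]1CO` reads > 100000 nM and that too is a limit. Compound 3 `[N-]=[N+]=N[C@H]1C[C@H](n2cnc3c(N)nc(Cl)nc32)O[C@@H]1CO` reads > 100000 nM which is again a limit. Compound 1 therefore shares its standing with both, and no order can be drawn. The change to compound 4 `[N-]=[N+]=N[C@H]1C[C@H](n2cnc3c(NCCO)nc(N)nc32)O[C@@H]1CO` is 2-hydroxyethyl in place of 1-(hydroxymethyl)-1-methylethyl on a nitrogen on an aromatic ring and it puts 2-hydroxyethyl in place of 1-(hydroxymethyl)-1-methylethyl on a nitrogen on an aromatic ring. The nearest measured change at that place is a step that the two limits leave unreadable from compound 2 to compound 3 and the evidence is the limit of > 100000 nM in this assay, at which 3 of the 3 values shown sit, so no size can be carried over. Thus a number no higher from compound 1 to compound 4 (the limit leaves the size open) is expected to stay within the scatter, in neither direction. Compound 4 is estimated at 100000 nM with an expected range from 30000 nM to 300000 nM and may well report only a limit.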

Compound 4, half-maximal inhibitory concentration: > 100000 nM
Compound 4: a limit, no number; the forecaster's own chance of this, stated with the estimate: 85%; the middle value lies on the limit itself.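

For the compounds shown here, compound 1 and compound 4 each give only a limit and not a number, so no step between them can be read. The compounds shown leave open whether 2-hydroxyethyl or 1-(hydroxymethyl)-1-methylethyl on that nitrogen makes any difference.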